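A few compounds are considered here, and "the series" means these few. Any claim that something is new, unique, unknown or untested is made for them only; others in the source may bear on it.

Measured compounds in an ADME assay on Vero cells (Chlorocebus sabaeus) for cytotoxicity, with a stated time of 7 days; a lower number here means that less compound is tolerated, a higher number that more compound is tolerated:

compound 1 `COc1cccc(CN2C(=O)CN(C(=O)c3cc4cc(OC)ccc4[nH]3)C[C@@H]2Cc2ccccn2)c1` gives > 10000 nM
compound 2 `COc1ccc2[nH]c(C(=O)N3CC(=O)N(Cc4ccccc4)[C@@H](N4[C@H](C)CCC[C@@H]4C)C3)cc2c1` gives 1400 nM

The value of compound 1 is a limit of the assay and not a number, as the limit of > 10000 nM in this assay, at which 1 of the 2 values shown sits, shows. Compound 2 therefore stands as the only number shown in this assay; the one further value is a limit, so no measured step between compounds differing in one place is available from these two.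

Compound 3 `COc1ccc2[nH]c(C(=O)N3CC(=O)N(Cc4ccccc4)[C@@H](CN4CC5CC5C4)C3)cc2c1` differs from compound 2 in one place: a group of 7 heavy atoms (6 carbon, 1 nitrogen; one three-membered non-aromatic ring of carbon only, one five-membered non-aromatic ring with 1 hetero atom) in place of a group of 8 heavy atoms (7 carbon, 1 nitrogen; one six-membered non-aromatic ring with 1 hetero atom), on a saturated ring carbon. Among the compounds with values here, no measured pair shows a change of this kind, so the data give no reading of its size or direction. The expected step in this assay from compound 2 to compound 3 is a 1.3-fold higher number from compound 2 to compound 3 (0.11 log units; within the scatter), which is taken as none beyond the usual scatter. Compound 3 is accordingly expected to give about 1800 nM in this assay, with a range from 600 nM to 6000 nM.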

Compound 3, half-maximal cytotoxic concentration: 13800 nM
For compound 3 the middle estimate is 7.7-fold (0.88 log units) below the measured one; measured number outside the range, above it.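

In this assay, replacing 2,6-dimethylpiperidin-1-yl on this saturated ring carbon with the group carrying a three-membered carbon ring and a five-membered ring gives a 9.9-fold higher number from compound 2 to compound 3 (0.99 log units; beyond the scatter), so the group at this position can move the tolerated concentration beyond the scatter. Both groups have the same counts of hydrogen-bond donors and acceptors and no net charge, so these counts do not separate them. Nothing given here accounts for the size or direction of this step.

This single pair cannot separate the part played by the two methyl groups and their defined stereocentres from that of the ring system. On these data alone, whether a morpholine, a simple dimethylamino group or a carboxylic acid at this carbon would follow the same direction remains open.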